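This account rests on a few compounds, and the source may have more. Where it says the series, first, only, none or still open, it means among the compounds named here.

Working notes on the series.

Compound 1 `Cc1cccc(-c2nc(C(F)(F)F)n(CC[C@@H](O)C[C@@H](O)CC(=O)O)c2-c2ccc(F)cc2)c1` and compound 2 `COc1cccc(-c2nc(C(F)(F)F)n(CC[C@@H](O)C[C@@H](O)CC(=O)O)c2-c2ccc(F)cc2)c1` share one core. In an assay on microsomes from liver for inhibition of 3-hydroxy-3-methylglutaryl-coenzyme A reductase (Rattus norvegicus) (a higher number here means a weaker inhibitor, a lower number a stronger inhibitor), compound 1 gives 29 nM and compound 2 gives 20 nM. The change between them, (methoxy in place of methyl on an aromatic carbon), makes a 1.5-fold lower number from compound 1 to compound 2 (0.16 log units; within the scatter).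

Compound 3 `Cc1cccc(-c2c(-c3ccc(F)cc3)nc(C(F)(F)F)n2CC[C@@H](O)C[C@@H](O)CC(=O)O)c1` is built on a second core; how the two cores differ is not broken down here. In this assay compound 3 gives 74 nM, the highest number of the three measured compounds.

Compound 4 `COc1cccc(-c2c(-c3ccc(F)cc3)nc(C(F)(F)F)n2CC[C@@H](O)C[C@@H](O)CC(=O)O)c1` differs from compound 3 by methoxy in place of methyl on an aromatic carbon, the same change as from compound 1 to compound 2 and at the same place. On the second core the step is expected to be similar to the earlier one, that is a 1.5-fold lower number from compound 3 to compound 4 (0.17 log units; within the scatter), because a 1.5-fold lower number from compound 1 to compound 2 (0.16 log units; within the scatter) stayed within the scatter. Compound 4 is therefore estimated at 50 nM in this assay, with a likely range of 25 nM to 100 nM.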

Compound 4, half-maximal inhibitory concentration: 135 nM
Beside the measured number, compound 4's estimate is 2.7-fold (0.43 log units) below it; measured number above the stated range.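

In this assay, methoxy in place of methyl gives a 1.8-fold higher number from compound 3 to compound 4 (0.26 log units; within the scatter), so on the core of compound 3 this step stays within the scatter, as it did on the core of compound 1. The two steps, set side by side, do not differ by more than repeated measurements allow: the same change on two cores in this assay, a 1.5-fold lower number (0.16 log units; within the scatter) from compound 1 to compound 2 and a 1.8-fold higher number (0.26 log units; within the scatter) from compound 3 to compound 4, 2.6-fold (0.42 log units) apart, within the scatter of two such steps. This is consistent with the change carrying across both cores with little effect, but two pairs, each within the scatter, neither prove that the change is neutral on either core nor give either step a real direction.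

The compounds shown leave open whether a different group at this place on the aromatic ring, such as an amine or a chlorine atom, would give a step beyond the scatter on either core.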